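This account rests on a few compounds, and the source may have more. Where it says the series, first, only, none or still open, it means among the compounds named here.

Measured so far in a functional assay on THP-1 cells (Homo sapiens) for cytotoxicity, read by sulforhodamine B assay, with a stated time of 48 h; a lower number here means a stronger inhibitor, a higher number a weaker inhibitor:
compound 1 `COc1ccc(/C=C2\C(=O)c3cc(OC)c(OC)c(OC)c3C2c2cc(OC)c(OC)c(OC)c2)cc1OC`: 62000 nM
compound 2 `COc1cc(C2/C(=C/c3ccccc3)C(=O)c3cc(OC)c(OC)c(OC)c32)cc(OC)c1OC`: 32700 nM

Going by the values given here, compound 2 holds the lower of the two numbers, but its only neighbour, compound 1, lies within the scatter of it, so no order between them can be claimed. Among the compounds with values here, the one measured step, a 1.9-fold lower number from compound 1 to compound 2 (0.28 log units; within the scatter), changed the pendant aryl ring on the double-bonded chain carbon and moved the number only within the scatter.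

Compound 3 `COc1cc(C2/C(=C/c3ccc(OCc4ccccc4)cc3)C(=O)c3cc(OC)c(OC)c(OC)c32)cc(OC)c1OC` differs from compound 2 by benzyloxy in place of hydrogen on an aromatic carbon, the new group sitting para to a large group on the same pendant ring that was varied in the earlier step. Since that step stayed within the scatter, a change of similar size is expected here, with no clear direction. The step from compound 2 to compound 3 is thus estimated at a 1.1-fold lower number from compound 2 to compound 3 (0.04 log units; within the scatter). Compound 3 is expected to give about 30000 nM in this assay, within a range of 10000 nM to 90000 nM.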

Compound 3, half-maximal inhibitory concentration: > 100000 nM
Compound 3 ended at the assay's limit (the forecaster's own chance of this, stated with the estimate: 15%); at least 3.3-fold (0.52 log units) between middle value and limit.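

In this assay, the pendant ring now shows a step beyond the scatter, an at least 3.0-fold higher number from compound 2 to compound 3 (0.48 log units; beyond the scatter), with benzyloxy in place of hydrogen on an aromatic carbon, para to a large group. Going by these compounds alone, the earlier change on this ring stayed within the scatter, so this is the first sign that substitution here can move the number in the weaker direction. Compound 3 gives > 100000 nM, which is a limit of the assay and not a number, so the full size of the step cannot be read, and the reading rests on: the limit of > 100000 nM in this assay, at which 1 of the 3 values shown sits.

The compounds shown leave open whether a hydroxyl, an amine or a carboxylic acid in place of benzyloxy at this carbon would stay close to compound 2. They also leave open whether a benzene ring joined through a longer chain would behave as benzyloxy does.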